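A few compounds are considered here, and "the series" means these few. Any claim that something is new, unique, unknown or untested is made for them only; others in the source may bear on it.

Compound 1 `O=C(/C=C/c1cccc(NS(=O)(=O)c2cccc(Cl)c2)c1)c1nc2ccccc2[nH]1`: 52.6%
Compound 2 `Cc1ccccc1S(=O)(=O)Nc1cccc(/C=C/C(=O)c2nc3ccccc3[nH]2)c1`: 47.8%

In an assay on isolated protein for inhibition of cathepsin S (Homo sapiens), read by fluorescence, with stated times of 15 min and 30 min, tested at 5 uM (a higher number here means more inhibition at the concentration tested (going by the name of the read-out), a lower number less inhibition), compound 2 gives 47.8%, the lowest of the two numbers, though its nearest neighbour compound 1 lies within the scatter a number 4.8 percentage points lower from compound 1 to compound 2 (within the scatter). Compound 3 `Cc1ccc(S(=O)(=O)Nc2cccc(/C=C/C(=O)c3nc4ccccc4[nH]3)c2)cc1` differs from compound 2 only by the sulfonyl substituent: 4-methylphenyl in place of 2-methylphenyl on a sulfonyl sulfur. Among the compounds with values here, the one measured step that touches this position, the exchange of the aryl group on the sulfonyl sulfur, stayed within the scatter, so no shift beyond the scatter is expected here either, with the estimated step of a number 0.2 percentage points higher from compound 2 to compound 3 (within the scatter) near nil. Compound 3 is therefore expected at 48%, with a range from 30% to 65%.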

Compound 3, a percentage reported as inhibition, at one concentration (the size of the read-out at that concentration, not a potency): 22%
Compound 3: middle estimate off by 26 percentage points, on the high side; the whole stated range lies above it.
By their numbers in this assay, from the lowest: compound 3; then compounds 2 and 1 (each within the scatter of the next).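

The aryl group on the sulfonyl sulfur is not a silent place after all: with the same atoms, 4-methylphenyl in place of 2-methylphenyl gives a number 25.8 percentage points lower from compound 2 to compound 3 (beyond the scatter) while the earlier exchange there stayed within the scatter. Measured against 3-chlorophenyl, the same group gives a number 30.6 percentage points lower from compound 1 to compound 3 (beyond the scatter) so among these three compounds only compound 3 stands apart. From the compounds shown here alone, whether a plain phenyl, or an amine or a carboxylic acid on that aryl group, would follow compound 3 or compound 2 remains open. Nothing at hand accounts for the drop.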